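Half-life of compound 3 after a methyl-to-chloro swap

The source may report more compounds than this note shows. Statements on the series, on what has been measured and on what is new or still open speak of the compounds shown alone.

Measured compounds:
Compound 1 `Cc1ccc([C@@H](C)Oc2cc3onc(CCC(=O)O)c3cc2Cl)nc1`: 3.6 h
Compound 2 `O=C(O)CCn1c(=O)oc2cc(OCC3CC3)c(Cl)cc21`: 0.68 h

In an ADME assay on the whole organism (strain Han-Wistar) for metabolic stability, with Rattus norvegicus as the target, read by LC-MS, at a dose of 1 mg/kg by the intravenous route (a higher number here means that the compound lasts longer, a lower number that the compound disappears faster), compound 1 gives 3.6 h, the highest of the two numbers. Compound 2 gives 0.68 h, and the gap between the two lies beyond the scatter.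

Compound 3 `C[C@@H](Oc1cc2onc(CCC(=O)O)c2cc1Cl)c1ccc(Cl)cn1` has not yet been measured. It departs from compound 1 in a single place: chloro in place of methyl on an aromatic carbon. In words, this is chloro in place of methyl on an aromatic carbon, which turns 5-methylpyridin-2-yl into 5-chloropyridin-2-yl.

For the measured compounds named here, no two measured compounds differ in only one place, so the data give no direct measure of what this swap does. The expectation therefore starts from compound 1 at 3.6 h, and no step beyond the scatter is expected in this assay. The estimated 1.4-fold higher number from compound 1 to compound 3 (0.14 log units; within the scatter) is a small rise that stays within the scatter. For compound 3 the expected half-life is 5 h, with an estimated range from 2.4 h to 10 h.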

Compound 3, half-life in the Rattus norvegicus assay: 8.7 h
For compound 3 the middle estimate is 1.7-fold (0.24 log units) below the measured one; measured number inside the range.
By their numbers in the Rattus norvegicus assay, from the lowest: compound 2; then compound 1; then compound 3.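

In the Rattus norvegicus assay, replacing methyl with chloro on an aromatic carbon, two atoms from the ring nitrogen and para to a large group, gives a 2.4-fold higher number from compound 1 to compound 3 (0.38 log units; beyond the scatter), a modest rise and the only single-place step among the compounds shown, so this one group on the 5-methylpyridin-2-yl ring, now 5-chloropyridin-2-yl, is enough to move the half-life beyond the scatter. Nothing measured for these compounds bears on why the half-life rises with this change. In a physicochemical assay for solubility, with a stated time of 24 h (a lower number here means a less soluble compound, a higher number a more soluble compound), compound 1 gives only a limit, > 860 ug/mL, and not a number.

In the physicochemical assay compound 3 likewise gives only a limit, > 620 ug/mL, so the step between the two limits cannot be read. From the compounds shown here alone, how a fluoro, a nitrile or a methoxy group at this same place would compare with methyl and chloro remains open, as does whether the step from methyl to chloro carries over to a different core.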